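The source may report more compounds than this note shows. Statements on the series, on what has been measured and on what is new or still open speak of the compounds shown alone.

Compound 3 `CCc1ccc(N2CCCC(=O)N2)cc1` sits second highest among the three numbers measured in an assay on isolated protein for inhibition of Polyunsaturated fatty acid 5-lipoxygenase (Homo sapiens) (on this read-out higher numbers stand for weaker inhibition and lower numbers for stronger inhibition), where compound 3 gives 125000 nM. Going by the values given here, its nearest neighbour is compound 2 `Cc1ccc(N2CCCC(=O)N2)cc1`, which in this assay gives 277000 nM, and the furthest is compound 1 `Cc1cccc(N2CCCC(=O)N2)c1`, which in this assay gives 3400 nM; the two values of compound 1 and compound 3 show compound 1 with the markedly lower number, though no single-point step links them. Among the compounds with values here, the one step that connects measured compounds, a 2.2-fold lower number from compound 2 to compound 3 (0.35 log units; beyond the scatter), comes from methyl in place of hydrogen on a saturated chain carbon bound to an aromatic carbon.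

Compound 4 `O=C1CCCN(c2ccc(Cl)cc2)N1` differs from compound 3 by chloro in place of ethyl on an aromatic carbon. The step from compound 2 to compound 3 bears on this change only loosely: it shows that altering the group at the same place, on an aromatic carbon para to a group of 7 heavy atoms, moved the number in this assay by a modest amount, and nothing measured here involves chloro. Compound 4 is therefore expected to give a number close to that of compound 3, with the estimated step of a 1.3-fold higher number from compound 3 to compound 4 (0.11 log units; within the scatter) not clearly beyond the scatter. The estimate for compound 4 in this assay is 160000 nM, within a range from 40000 nM to 640000 nM.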

Compound 4, half-maximal inhibitory concentration: 79000 nM
Beside the measured number, compound 4's estimate is 2.0-fold (0.31 log units) above it; measured number inside the range.
By their numbers in this assay, from the lowest: compound 1; then compounds 4 and 3 (each within the scatter of the next); then compound 2.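

With chloro in place of ethyl on an aromatic carbon, para to a group of 7 heavy atoms, the result is (a 1.6-fold lower number from compound 3 to compound 4 (0.20 log units; within the scatter)) in this assay, so this read-out does not separate the two groups, although ethyl has 2 heavy atoms and chloro has 1. Chloro in place of methyl at the same position does give a separation (a 3.5-fold lower number from compound 2 to compound 4 (0.54 log units; beyond the scatter)), a modest one, so compound 2 remains apart from both compound 3 and compound 4, and the position is now shown to accept a group that is not a carbon chain without a large shift in the number. Nothing presented here gives a measured basis for explaining these steps.

The compounds shown leave open whether a group of another kind at this position, such as an amine, a carboxylic acid or a methoxy group, would move the number further than these modest steps. They also leave open whether chloro, placed where the methyl group of compound 1 stands, would give a number close to that of compound 1, which is 3400 nM.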